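The source may hold more compounds than are shown below. What is called first, only, known or untested is meant among the compounds shown, and "the series" means these compounds.

Measured so far in a functional assay on NCI-H3122 cells (Homo sapiens) for antiproliferative activity, read by MTT assay, with a stated time of 48 h; on this read-out higher numbers stand for weaker inhibition and lower numbers for stronger inhibition:
- Compound 1 `CC(Oc1cccnc1Nc1cnn(C)c1)c1cccc(C(=O)NCc2ccc(F)cc2)c1`: 43800 nM
- Compound 2 `CC(Oc1cccnc1Nc1cnn(C)c1)c1cccc(C(=O)NCc2ccc(OC(F)(F)F)cc2)c1`: 8300 nM
- Compound 3 `Cc1ccc(CNC(=O)c2cccc(C(C)Oc3cccnc3Nc3cnn(CC(C)(C)O)c3)c2)cc1`: 9100 nM

Compound 3 gives the second-highest of the three numbers; its value sits close to that of compound 2, and compound 1 gives a clearly higher number. Within the data shown here, the only measured step, a 5.3-fold lower number from compound 1 to compound 2 (0.72 log units; beyond the scatter), concerns the aryl substituent of the benzylamide and is modest in size.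

Compound 4 `Cc1ccc(CNC(=O)c2cccc(C(C)Oc3cccnc3Nc3cnn(CC#N)c3)c2)cc1` differs from compound 3 by cyano in place of 1-hydroxy-1-methylethyl on a saturated chain carbon bound to an aromatic nitrogen. Among the measured compounds shown here, no measured pair changes this position, so the step from compound 1 to compound 2 does not bear on it directly and offers no direction. With nothing to anchor a shift, the expectation for compound 4 is a number near that of compound 3, the step of a 1.0-fold lower number from compound 3 to compound 4 (0.00 log units; within the scatter) lying within the scatter, giving an estimate of 9000 nM with a range from 3000 nM to 27000 nM.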

Compound 4, half-maximal inhibitory concentration: 38400 nM
Compound 4: the middle estimate sits 4.3-fold (0.63 log units) below what was measured; measured number above the stated range.
By their numbers in this assay, from the lowest: compounds 2 and 3 (each within the scatter of the next); then compounds 4 and 1 (each within the scatter of the next).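

In this assay the record shows a 4.2-fold higher number from compound 3 to compound 4 (0.63 log units; beyond the scatter) when cyano replaces 1-hydroxy-1-methylethyl on a saturated chain carbon bound to an aromatic nitrogen. Among these compounds, this is the first sign that this place matters, since no earlier pair varied it, and here the change goes toward weaker inhibition. Nothing available explains the shift.

The compounds shown leave open how an amine, a carboxylic acid or a longer chain would read at this place. They also leave open whether the step would hold with the trifluoromethoxy benzylamide of compound 2.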